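The compounds below may be only part of what the source reports. "The series", "measured", "known", "first", "only" and "open" are said of these compounds alone.

Of the compounds shown here, two from this series have been measured so far. Compound 1, `CC(C)(C)OC(=O)N1CCN(C(=S)SCc2cn(Cc3ccc(Cl)cc3)nn2)CC1`, gives 2960 nM in a functional assay on MCF7 cells (Homo sapiens) for inhibition, read by MTT assay, with a stated time of 72 h; a lower number here means a stronger inhibitor, a higher number a weaker inhibitor. Compound 2, `O=C(OCc1ccccc1)N1CCN(C(=S)SCc2cn(Cc3ccc(F)cc3)nn2)CC1`, gives 10300 nM in this assay. Among the compounds with values here, compound 2 stands at the highest number of the two, and its nearest neighbour, compound 1, sits below it by a margin that is beyond the usual scatter of this kind of measurement; no single-point step between these two measured compounds is available, since they differ in more than one place.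

Compound 3, `COc1cc(Cn2cc(CSC(=S)N3CCN(C(=O)OCc4ccccc4)CC3)nn2)cc(OC)c1OC`, has not yet been measured in this assay. It differs from compound 2 in one place: 3,4,5-trimethoxyphenyl in place of 4-fluorophenyl on a saturated chain carbon bound to an aromatic nitrogen. Within the data shown here, with no measured step that isolates a change of this kind, there is no firm basis for predicting its direction. The step from compound 2 to compound 3 is therefore expected to be small, a 1.5-fold lower number from compound 2 to compound 3 (0.17 log units; within the scatter), and likely within the scatter. On that basis compound 3 is estimated to give 7000 nM in this assay, with a plausible range from 2500 nM to 20000 nM.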

Compound 3, half-maximal inhibitory concentration: > 128000 nM
Compound 3: no number, only a limit (the forecaster's own chance of this, stated with the estimate: 10%); at least 18-fold (1.26 log units) between middle value and limit.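

Within the data shown here, the place on a saturated chain carbon bound to an aromatic nitrogen proves sensitive to the ring it carries: in this assay, 3,4,5-trimethoxyphenyl in place of 4-fluorophenyl gives an at least 12-fold higher number from compound 2 to compound 3 (1.09 log units; beyond the scatter), the first single-place change and a large one. Compound 3 gives > 128000 nM, which is a limit of the assay and not a number, so the printed step gives only the smallest size the change can have. Of the compounds shown, only compound 3 stands at this edge of the assay's range: the limit of > 128000 nM in this assay, at which 1 of the 3 values shown sits.

The compounds shown do not tell whether the three methoxy groups act together or whether one alone would be enough, and a 4-methoxyphenyl or a plain phenyl at this place would separate those readings. As far as these compounds go, it also remains open whether the same exchange has a comparable effect when the benzyl carbamate of compound 3 is replaced by the tert-butyl carbamate of compound 1, and how far above the limit compound 3 truly lies.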